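Aryl Group Replaces Methyl on a Furan Ester

The source may hold more compounds than are shown below. What is called first, only, known or untested is meant among the compounds shown, and "the series" means these compounds.

Measured so far in an assay on isolated protein for inhibition of high affinity 3',5'-cyclic-AMP phosphodiesterase 7A (Homo sapiens), read by scintillation proximity assay and cAMP accumulation, with a stated time of 20 min, tested at 10 uM; a lower number here means less inhibition, a higher number more inhibition at the concentration tested (going by the name of the read-out):
compound 1 `COc1cc(C(=O)OCc2ccc(-c3ccc(Cl)cc3Cl)o2)cc(OC)c1OC`: 24.4%
compound 2 `CCOc1cc(C(=O)OCc2ccc(-c3ccc(Cl)cc3Cl)o2)cc(OCC)c1OCC`: 3.7%
compound 3 `COc1cc(COC(=O)c2ccc(C)o2)cc(OC)c1OC`: -9.9%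

Compound 3 stands lowest of the three numbers. Its nearest neighbour is compound 2, whose value lies higher by more than the scatter, and compound 1 lies higher still, again beyond the scatter. Compound 3 is the only one of the three that carries a methyl rather than a chlorinated phenyl on the five-membered ring, and it is also the one with no inhibition.

Compound 4 `COc1cc(COC(=O)c2ccc(-c3ccccc3Cl)o2)cc(OC)c1OC` differs from compound 3 in one place: 2-chlorophenyl in place of methyl on an aromatic carbon. Because compound 1 gives 24.4% and compound 2 gives 3.7%, both above compound 3, a rise beyond the scatter is expected for this change, though a modest one. The step of a number 21.9 percentage points higher from compound 3 to compound 4 (beyond the scatter) is the estimated gain. Compound 4 is expected to reach 12%, in the range -5% to 30%.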

Compound 4, a percentage reported as inhibition, at one concentration (the size of the read-out at that concentration, not a potency): 34.6%
Estimate against measurement, compound 4: 22.6 percentage points below, outside the stated range (above it).
By their numbers in this assay, from the lowest: compound 3; then compound 2; then compound 1; then compound 4.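

In this assay the change from methyl to 2-chlorophenyl, on the aromatic carbon next to the ring oxygen, gives a step of a number 44.5 percentage points higher from compound 3 to compound 4 (beyond the scatter) and is the only change in one place among the compounds shown. For the compounds shown here, it shows that the read-out responds directly to the group on this carbon, which the earlier compounds, differing in several places, could not show. No measurement shown accounts for the size of this step.

The compounds shown leave open whether the chlorine is needed for this rise, and whether an unsubstituted phenyl, an amine or a longer chain on the same carbon would give a similar one.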